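The source may hold more compounds than are shown below. What is called first, only, known or untested is meant among the compounds shown, and "the series" means these compounds.

Of the compounds shown here, three that share one core have been tested in a functional assay on WiDr cells (Homo sapiens) for antiproliferative activity, read by sulforhodamine B assay, with a stated time of 48 h; on this read-out lower numbers stand for stronger inhibition of growth and higher numbers for weaker inhibition of growth. Compound 1 `CCCCCCCC1C=C(Cl)CCN1S(=O)(=O)c1ccc(C)cc1` gives 50000 nM. Compound 2 `Cc1ccc(S(=O)(=O)N2CCC(Cl)=CC2c2ccccc2)cc1` gives 18000 nM, and the step of a 2.8-fold lower number from compound 1 to compound 2 (0.44 log units; beyond the scatter), a phenyl in place of a heptyl on a saturated ring carbon, is modest but beyond the scatter. Compound 3 `CCCCCCCC1C=C(Br)CCN1S(=O)(=O)c1ccc(C)cc1` gives 40000 nM; the step of a 1.3-fold lower number from compound 1 to compound 3 (0.10 log units; within the scatter) is within the scatter, so those two numbers cannot be ordered. Among the three numbers compound 3 stands second highest, nearest to compound 1 and furthest from compound 2.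

Compound 4 `Cc1ccc(S(=O)(=O)N2CCC(Br)=CC2c2ccccc2)cc1` has not yet been measured. The change phenyl in place of heptyl on a saturated ring carbon repeats, on the bromo-bearing core, the swap that separates compound 2 from compound 1. For the measured compounds named here, only that step, a 2.8-fold lower number from compound 1 to compound 2 (0.44 log units; beyond the scatter), bears on it directly, and it was measured on the chloro analogues rather than on compound 3. Going by the values given here, no phenyl compound carrying a bromo group has been seen, so whether the two substitutions interact is unknown. A shift of the same modest size, toward a lower number, is therefore expected in this assay: a 2.9-fold lower number from compound 3 to compound 4 (0.46 log units; beyond the scatter). Compound 4 is accordingly estimated at 14000 nM, with a range from 6000 nM to 32000 nM.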

Compound 4, concentration for 50% growth inhibition: 29000 nM
Estimate against measurement, compound 4: 2.1-fold (0.32 log units) below; the range from low to high includes it.
By their numbers in this assay, from the lowest: compounds 2, 4, 3 and 1 (each within the scatter of the next, the first and the last beyond it).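

On the bromo-bearing core, phenyl in place of heptyl on the saturated ring carbon next to the ring nitrogen gives a 1.4-fold lower number from compound 3 to compound 4 (0.14 log units; within the scatter) in this assay, so the shift seen on the chloro compounds cannot be read on this core, yet the two steps cannot be told apart: the same change on two cores in this assay, a 2.8-fold lower number (0.44 log units; beyond the scatter) from compound 1 to compound 2 and a 1.4-fold lower number (0.14 log units; within the scatter) from compound 3 to compound 4, 2.0-fold (0.30 log units) apart, within the scatter of two such steps

The other change, bromo in place of chloro on a double-bonded ring carbon, now has a step on the phenyl compounds as well, a 1.6-fold higher number from compound 2 to compound 4 (0.21 log units; within the scatter), so it stays unreadable on both cores, and these two steps also agree: the same change on two cores in this assay, a 1.3-fold lower number (0.10 log units; within the scatter) from compound 1 to compound 3 and a 1.6-fold higher number (0.21 log units; within the scatter) from compound 2 to compound 4, 2.0-fold (0.30 log units) apart, within the scatter of two such steps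

Of the four steps between these compounds, only a 2.8-fold lower number from compound 1 to compound 2 (0.44 log units; beyond the scatter) lies beyond the scatter, so the case for phenyl over heptyl rests on that single pair, and the four numbers show no readable interaction between the two changes.

The compounds shown leave open whether a shorter chain such as butyl, or a phenyl ring carrying an amine or a carboxylic acid, on this saturated ring carbon would move the number further than phenyl does. They also leave open how iodo or a nitrile on the double-bonded ring carbon would compare with chloro and bromo.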